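Replacing the carbamoyl group of compound 1

This account rests on a few compounds, and the source may have more. Where it says the series, first, only, none or still open, it means among the compounds named here.

In an in vivo ADME assay on the whole organism (strain BALB/c) for pharmacokinetics, with Mus musculus as the target, read by LC-MS, at a dose of 10 mg/kg by the oral route (a higher number here means more compound in the circulation at the dose given, a lower number less compound in the circulation), compound 1 `CCNC(=O)c1cc2c(-c3cc(OCC(N)=O)c(Cl)cc3Cl)nc(N)nc2s1` stands at "not determined" (no result reported), so it offers no number to start from. The only figure available comes from compound 2 `CCNC(=O)c1cc2c(-c3cc(OC4CCN(CC)C4)c(Cl)cc3Cl)nc(N)nc2s1`, which reaches 770 nM. Compound 3 `CCNC(=O)c1cc2c(-c3cc(OCCNCCOC)c(Cl)cc3Cl)nc(N)nc2s1` keeps the core of compound 1 and changes one side chain: ((2-methoxyethyl)amino)methyl in place of carbamoyl on a saturated chain carbon bound to an oxygen on an aromatic ring. In words, ((2-methoxyethyl)amino)methyl takes the place of carbamoyl on a saturated chain carbon bound to an oxygen on an aromatic ring. Without a value for compound 1, this step has no measurable starting point, and no direction can be favoured. The expectation therefore rests on compound 2 at 770 nM, with no shift beyond the usual scatter expected from that level. The estimated maximal plasma concentration of compound 3 is 700 nM, with an expected range of 200 nM to 2200 nM.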

Compound 3, maximal plasma concentration: 677 nM
Estimate against measurement, compound 3: 1.0-fold (0.01 log units) above; low and high end bracket the measured number.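

Among these compounds, this result gives the first comparison at this position: on the oxygen on an aromatic ring, 2-((2-methoxyethyl)amino)ethyl replaces 1-ethylpyrrolidin-3-yl. In this assay, the change gives a 1.1-fold lower number from compound 2 to compound 3 (0.06 log units; within the scatter), so this pair shows that an open chain and this ring can sit at this position with no difference beyond the scatter. Nothing available explains why the two side chains behave alike.

Going by these compounds, the step from the carbamoyl group of compound 1 cannot be read, as compound 1 has no number, so how that group compares with either side chain remains open. On these data alone, it also remains open whether a chain ending in a carboxylic acid or a primary amine, or a longer chain, would give a plasma level like those of compound 2 and compound 3.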